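The source may report more compounds than this note shows. Statements on the series, on what has been measured and on what is new or still open speak of the compounds shown alone.

compound 1 `O=C(O)CCC1=C(c2ccc(Cl)cc2)NC(=S)NC1c1ccccc1O`: 1.22%
compound 2 `O=C(O)CCC1=C(c2ccccc2)NC(=S)NC1c1ccccc1O`: 12.9%
compound 3 `O=C(O)CCC1=C(c2ccccc2)NC(=S)NC1c1ccco1`: 9.81%

All three numbers come from a functional assay on the whole organism (strain Albino) for inhibition, with Rattus norvegicus as the target, with stated times of 1 h and 3 h, at a dose of 20 mg/kg by the oral route; on this read-out lower numbers stand for less inhibition and higher numbers for more inhibition at the one dose given (going by the name of the read-out). Compound 3 stands second highest of the three; its gap to compound 2, a number 3.1 percentage points lower from compound 2 to compound 3 (within the scatter), is within the scatter, and its gap to compound 1 is within the scatter as well. Compound 4 `O=C(O)CCC1=C(c2ccc(F)cc2)NC(=S)NC1c1ccco1` differs from compound 3 by fluoro in place of hydrogen on an aromatic carbon. Among the compounds with values here, the one measured step that bears on a halogen at this place is a number 11.7 percentage points higher from compound 1 to compound 2 (beyond the scatter), beyond the scatter, with the halogen-free compound the higher. Fluoro is not chloro, and no fluoro-bearing compound has been measured, so that step is the only guide. For compound 4 the step is therefore expected to be a number 3.8 percentage points lower from compound 3 to compound 4 (within the scatter), downward and near the edge of the scatter. The estimate for compound 4 is 6%, ranging from 0% to 14%.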

Compound 4, a percentage reported as inhibition, in the whole organism at one dose (the size of the read-out at that dose, not a potency): 3.68%
The estimate for compound 4 lay 2.3 percentage points above the measured number; measured number inside the range.
By their numbers in this assay, from the lowest: compounds 1, 4, 3 and 2 (each within the scatter of the next, the first and the last beyond it).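

Fluoro on the phenyl ring carrying no other substituent, with furan-2-yl on the saturated ring carbon, gives a number 6.1 percentage points lower from compound 3 to compound 4 (within the scatter), so this change at this place has no readable effect here. The earlier halogen step, a number 11.7 percentage points higher from compound 1 to compound 2 (beyond the scatter), involved chloro alongside 2-hydroxyphenyl, and fluoro alongside furan-2-yl does not establish the same effect. No measured evidence accounts for either step.

Open, going by these compounds, is whether chloro alongside furan-2-yl would match the fluoro result. Also open, on these data alone, is how a methoxy or amino group would read at this place.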